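Alpha-Alkyl Acid Series: Methyl Removal at the Chain Carbon

This account rests on a few compounds, and the source may have more. Where it says the series, first, only, none or still open, it means among the compounds named here.

The series is followed in a functional assay on HFL1 cells for antagonist activity at sphingosine 1-phosphate receptor 2 (Homo sapiens), read by ELISA, with a stated time of 24 h; on this read-out higher numbers stand for weaker inhibition and lower numbers for stronger inhibition. Compound 1 `CCC(C(=O)O)c1nn(Cc2cn3cc(OCC4CC4)c(Cl)cc3n2)c2ccccc2c1=O` gives 5.6 nM. Compound 2 `C[C@H](C(=O)O)n1nc(Cn2cc3cc(OCC4CC4)c(Cl)cc3n2)c2ccccc2c1=O` gives 3.5 nM; the two numbers lie within the usual scatter, so no order between them is read. For the measured compounds named here, compound 1 thus stands at the higher of the two numbers measured so far, with compound 2 as its only comparator.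

Compound 3 `CC(C(=O)O)c1nn(Cc2cn3cc(OCC4CC4)c(Cl)cc3n2)c2ccccc2c1=O` is not yet measured. Against compound 1 the difference is hydrogen in place of methyl on a saturated chain carbon, two bonds along the chain from an aromatic carbon and a carbonyl carbon, so the 1-carboxypropyl becomes a 1-carboxyethyl. Going by the values given here, no measured pair shows this step, and its size is therefore unknown from the data. A small step is expected, if anything a slight weakening in this assay, estimated as a 1.3-fold higher number from compound 1 to compound 3 (0.10 log units; within the scatter). For compound 3 the expected value in this assay is 7 nM, with a range from 2.5 nM to 20 nM.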

Compound 3, half-maximal inhibitory concentration: 1.3 nM
Compound 3: middle estimate off by 5.4-fold (0.73 log units), on the high side; the measured number lies below the stated range.
By their numbers in this assay, from the lowest: compound 3; then compounds 2 and 1 (each within the scatter of the next).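

At the saturated chain carbon, two bonds along the chain from an aromatic carbon and a carbonyl carbon, the change from 1-carboxypropyl to 1-carboxyethyl in this assay gives a 4.3-fold lower number from compound 1 to compound 3 (0.63 log units; beyond the scatter), so this position responds to the loss of a single carbon. The step runs towards stronger inhibition and lies beyond the scatter, although no ring, hydrogen-bond donor, hydrogen-bond acceptor or net charge enters or leaves. No measurement shown here bears on what lies behind this step.

The compounds shown leave open whether the gain continues with a plain carboxymethyl group, with hydrogen replacing the remaining methyl, or reverses with a longer chain such as 1-carboxybutyl. Also open, from the compounds shown here alone, is how a second methyl on this carbon, or a cyclopropyl ring built on it, would read.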